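This account rests on a few compounds, and the source may have more. Where it says the series, first, only, none or still open, it means among the compounds named here.

Measured in an assay on isolated protein for displacement of a labelled ligand from metabotropic glutamate receptor 5 (Homo sapiens), with a stated time of 60 min, tested at 1 uM; on this read-out lower numbers stand for less inhibition and higher numbers for more inhibition at the one concentration tested (going by the name of the read-out):
compound 1 `CC1CCN(c2c(S(=O)(=O)c3cc(F)cc(F)c3)cnc3cc(Cl)ccc23)CC1`: 94%
compound 2 `CC1CCN(c2c(S(=O)(=O)c3cccc(Cl)c3)cnc3cc(Cl)ccc23)CC1`: 92%
compound 3 `Cc1ccc2ncc(S(=O)(=O)c3ccc(Cl)cc3)c(N3CCC(C)CC3)c2c1`: 79%

Compound 2 stands second of the three, within the scatter of compound 1 and well clear of compound 3, which in this assay gives 79%.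

Compound 4 `Cc1ccc(S(=O)(=O)c2cnc3cc(Cl)ccc3c2N2CCC(C)CC2)cc1C` differs from compound 2 in one place: 3,4-dimethylphenyl in place of 3-chlorophenyl on a sulfonyl sulfur. Going by the values given here, the one measured step at the same place is a number 2 percentage points lower from compound 1 to compound 2 (within the scatter), within the scatter, so exchanging one substituted phenyl on the sulfonyl sulfur for another left this assay essentially unchanged. Among the compounds with values here, no measured step trades a chlorine for methyl groups, and compound 3 differs in two places, so it bears only loosely. The expected step is a number 4 percentage points lower from compound 2 to compound 4 (within the scatter), not beyond the scatter. Compound 4 is therefore estimated at 88%, between 72% and 97%.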

Compound 4, a percentage reported as inhibition, at one concentration (the size of the read-out at that concentration, not a potency): 86%
Beside the measured number, compound 4's estimate is 2 percentage points above it; low and high end bracket the measured number.
By their numbers in this assay, from the lowest: compounds 3, 4, 2 and 1 (each within the scatter of the next, the first and the last beyond it).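

Two further steps on the sulfonyl sulfur, a number 6 percentage points lower from compound 2 to compound 4 (within the scatter) and a number 8 percentage points lower from compound 1 to compound 4 (within the scatter), show the number in this assay staying level with 3,4-dimethylphenyl, a group with carbon substituents only. Chlorine or fluorine on this phenyl is therefore not needed for a reading in this range among compounds 1, 2 and 4. No measured property bears on this result.

Still open, going by these compounds, is whether an amine or a carboxylic acid on this phenyl would keep the reading. A single tested concentration also leaves the potencies of these compounds unresolved.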